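Phenyl to Thiophene: a Step Without a Precedent

A few compounds are considered here, and "the series" means these few. Any claim that something is new, unique, unknown or untested is made for them only; others in the source may bear on it.

Compound 3 `COc1ccc(C(=O)/C=C/c2ccccc2)c2c1C=CC(C)(C)O2` carries an unsubstituted phenyl on the double-bonded chain carbon. In a functional assay on SK-OV-3 cells (Homo sapiens) for antiproliferative activity, read by MTT assay, with a stated time of 24 h (a lower number here means a stronger inhibitor, a higher number a weaker inhibitor), compound 3 gives only a limit, > 10000 nM, and no number. Compound 2 `COc1ccc(C(=O)/C=C/c2ccc(C(F)(F)F)cc2)c2c1C=CC(C)(C)O2`, bearing trifluoromethyl on an aromatic carbon, likewise sits at a limit in this assay, > 10000 nM. Compound 1 `COc1ccc(C(=O)/C=C/c2ccc(N3CCCC3)cc2)c2c1C=CC(C)(C)O2`, with pyrrolidin-1-yl on that aromatic carbon, gives 7370 nM in this assay, so that the step of an at least 1.3-fold higher number from compound 1 to compound 3 (0.13 log units; that floor lies within the scatter) and the step of an at least 1.3-fold higher number from compound 1 to compound 2 (0.13 log units; that floor lies within the scatter) both rest at the scatter floor, while the step that the two limits leave unreadable from compound 2 to compound 3 cannot be read because the limit of > 10000 nM in this assay, at which 2 of the 3 values shown sit, holds two of the three values. Compound 4 `COc1ccc(C(=O)/C=C/c2cccs2)c2c1C=CC(C)(C)O2` differs from compound 3 by thiophen-2-yl in place of phenyl on a double-bonded chain carbon bound to a double-bonded chain carbon. Within the data shown here, no measured step covers this exchange; all three concern substituents on the aromatic carbon. The step that the limit leaves unreadable from compound 3 to compound 4 is expected to amount to essentially no change. For compound 4 the estimated value is 12000 nM, between 4000 nM and 40000 nM.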

Compound 4, half-maximal inhibitory concentration: > 10000 nM
Compound 4 ended at the assay's limit (the forecaster's own chance of this, stated with the estimate: 70%); the middle value is on the limit's open side.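

No step can be read between compound 3 and compound 4, because both stop at a limit: the limit of > 10000 nM in this assay, at which 3 of the 4 values shown sit.

On these data alone, whether thiophen-2-yl in place of phenyl changes the activity of the shared core in this assay stays open.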